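The source may report more compounds than this note shows. Statements on the series, on what has been measured and on what is new or still open speak of the compounds shown alone.

Working notes on the series of diacids. Compound 1 `Cc1c(Cl)cccc1CCCCOc1ccc(C#Cc2cccc3c(CC(=O)O)c(C)n(CCCCC(=O)O)c23)cc1` is the point of departure. In a physicochemical assay for permeability, using PAMPA, with a stated time of 4 h, at pH 7.4, tested at 50 uM (on this read-out higher numbers stand for higher permeability and lower numbers for lower permeability), compound 1 gives 1 10^-6 cm/s. Compound 3 `O=C(O)CCCn1cc(CC(=O)O)c2c(/C=C/c3ccc(OCCCCOc4ccccc4)cc3)cccc21` gives 1.8 10^-6 cm/s in this assay, and compound 2 `Cc1c(CCCC(=O)O)c2cccc(/C=C/c3ccc(OCCCCc4c(F)c(F)cc(F)c4F)cc3)c2n1CC(=O)O` gives 0.5 10^-6 cm/s. Of these three numbers compound 1 stands second highest; its separation from compound 3 and its separation from compound 2 both fall within the usual scatter of repeated measurements, so no ordering of the three can be read from them.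

Compound 4 `Cc1c(Cl)cccc1CCCCOc1ccc(C#Cc2cccc3c(CCCC(=O)O)c(C)n(CCCCC(=O)O)c23)cc1` is the next member and has not yet been measured in this assay. It differs from compound 1 in one place: 2-carboxyethyl in place of carboxy on a saturated chain carbon bound to an aromatic carbon. Among the compounds with values here, no measured pair in the set differs by this same change, so there is no measured step to set it against; the group that leaves is carboxy, the group that enters is 2-carboxyethyl, and nothing among the measured compounds shows how such a change reads out. The step expected from compound 1 to compound 4 is a 1.2-fold higher number from compound 1 to compound 4 (0.08 log units; within the scatter), estimated to stay within the scatter. For compound 4 the estimated value is 1.2 10^-6 cm/s, with a range from 0.5 10^-6 cm/s to 3 10^-6 cm/s.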

Compound 4, apparent permeability: 5 10^-6 cm/s
Compound 4: the middle estimate sits 4.2-fold (0.62 log units) below what was measured, and the stated range ends below it.
By their numbers in this assay, from the lowest: compounds 2, 1 and 3 (each within the scatter of the next, the first and the last beyond it); then compound 4.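

In this assay, within the data shown here, replacing carboxymethyl with 3-carboxypropyl on the core of compound 1 gives a 5.0-fold higher number from compound 1 to compound 4 (0.70 log units; beyond the scatter), the only one-place step measured so far and one that lies beyond the scatter. This place on the core is therefore not silent to the change: with the rest of compound 1 held constant, the chain carrying this acid moves the read-out on its own. No measurement at hand accounts for the size or direction of the step.

The compounds shown leave open whether a still longer chain at this place, or a primary amide or methyl ester in place of the terminal carboxylic acid, would extend, hold or reverse the step. From the compounds shown here alone, it also remains open whether the same change would read the same way on compound 3.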